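A few compounds are considered here, and "the series" means these few. Any claim that something is new, unique, unknown or untested is made for them only; others in the source may bear on it.

In a functional assay on MCF7 cells (Homo sapiens) for cytotoxicity, read by MTT assay, with a stated time of 48 h (a lower number here means a stronger inhibitor, a higher number a weaker inhibitor), the compounds read as follows:
Compound 1 `C/C(=N\NC(=S)Nc1ccc(Cl)cc1)c1ccccn1` at 8.49 nM
Compound 2 `CC(=NNC(=S)Nc1ccccc1F)c1ccccn1` at 0.39 nM
Compound 3 `C/C(=N\NC(=S)Nc1ccccc1Cl)c1ccccn1` at 0.16 nM

Compound 3 stands lowest of these three numbers, and both other compounds lie beyond the scatter from it. Compound 4 `C/C(=N\NC(=S)Nc1ccccc1[N+](=O)[O-])c1ccccn1` carries nitro in place of chloro on an aromatic carbon. Going by the values given here, no measured pair shows this exchange, so the expectation in this assay rests on little. A modest rise in the number is expected, because compound 3 at 0.16 nM already sits lowest of the three. The expected step is a 2.5-fold higher number from compound 3 to compound 4 (0.40 log units; beyond the scatter) and a fall cannot be ruled out. Compound 4 is estimated at 0.4 nM with 0.08 nM to 2.5 nM as its expected range.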

Compound 4, half-maximal inhibitory concentration: 5.7 nM
Estimate against measurement, compound 4: 14-fold (1.15 log units) below; the whole stated range lies below it.
By their numbers in this assay, from the lowest: compound 3; then compound 2; then compounds 4 and 1 (each within the scatter of the next).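

Going by these compounds alone, with only one compound changed in one place, this is the first step that can be read, and it shows that the aromatic carbon ortho to a large group is sensitive to its substituent in this assay: nitro in place of chloro gives a 36-fold higher number from compound 3 to compound 4 (1.55 log units; beyond the scatter), a large change. No measurement at hand accounts for the size of this step.

From the compounds shown here alone, whether an amine, a methoxy group or a carboxylic acid on this carbon would stay close to compound 3 at 0.16 nM or shift as nitro does remains open. Going by these compounds, whether this exchange elsewhere on the ring would give a similar step also remains open.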